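The compounds below may be only part of what the source reports. "The series", "measured", "known", "first", "only" and "open" are said of these compounds alone.

Compound 2 `O=[N+]([O-])c1cccc(Nc2nc(SCc3ccc(C(F)(F)F)cc3)nc3ccccc23)c1` stands at the edge of what the numbers show. In a functional assay on MCF7 cells (Homo sapiens) for cytotoxicity, read by MTT assay, with a stated time of 72 h (a higher number here means a weaker inhibitor, a lower number a stronger inhibitor), compound 2 gives only a limit, > 50000 nM, which is the limit of > 50000 nM in this assay, at which 1 of the 2 values shown sits. Compound 1 `FC(F)(F)c1ccc(CSc2nc(Nc3cccc(Cl)c3)c3ccccc3n2)cc1` gives 25100 nM in this assay. Within the data shown here, the single measured step, an at least 1.9-fold higher number from compound 1 to compound 2 (0.29 log units; that floor lies within the scatter), swaps the group itself and says nothing about moving a nitro group. Compound 3 `O=[N+]([O-])c1ccc(Nc2nc(SCc3ccc(C(F)(F)F)cc3)nc3ccccc23)cc1` differs from compound 2 by 4-nitrophenyl in place of 3-nitrophenyl on a nitrogen on an aromatic ring. Among the measured compounds shown here, no measured step bears on this change, so in this assay no step beyond the scatter is expected, and compound 3 is estimated at 50000 nM with a range of 20000 nM to 150000 nM. The expected step is a number no higher from compound 2 to compound 3 (the limit leaves the size open).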

Compound 3, half-maximal inhibitory concentration: 17900 nM
For compound 3 the middle estimate is 2.8-fold (0.45 log units) above the measured one; measured number below the stated range.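

In this assay, moving the nitro group on the ring carried by the nitrogen is a step beyond the scatter: an at least 2.7-fold lower number from compound 2 to compound 3 (0.44 log units; beyond the scatter). So 3-nitrophenyl and 4-nitrophenyl are not interchangeable here, a point the earlier chloro-to-nitro step could not show. From the compounds shown here alone, its true size stays open because compound 2 gives only a limit: the limit of > 50000 nM in this assay, at which 1 of the 3 values shown sits. Against the chloro compound, 4-nitrophenyl shows no separation: a 1.4-fold lower number from compound 1 to compound 3 (0.15 log units; within the scatter). The compounds shown leave open whether 4-chlorophenyl, or a phenyl carrying an amine or a carboxylic acid, would read like compound 3.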